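A few compounds are considered here, and "the series" means these few. Any claim that something is new, unique, unknown or untested is made for them only; others in the source may bear on it.

Measured so far:
- compound 1, `O=S(=O)(c1cccc(-c2ccc3nccc(-c4ccncc4)c3n2)c1)N1CCC(O)CC1`: 10000 nM
- compound 2, `CS(=O)(=O)c1cccc(-c2ccc3nccc(N4CCNCC4)c3n2)c1`: 165000 nM

Both numbers come from a physicochemical assay for solubility, read by HPLC, using the shake flask method, measured as kinetic solubility, with a stated time of 20 h, at pH 6.5, tested at 200 uM; on this read-out higher numbers stand for higher solubility and lower numbers for lower solubility. Compound 1 holds the lowest value of the two; compound 2 sits a long way above it, well beyond the scatter of repeated runs, but the two structures differ in more than one place, so nothing more than that comparison can be drawn from them.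

The step to follow leads from compound 1 to compound 3, `C[C@@H]1CN(S(=O)(=O)c2cccc(-c3ccc4nccc(-c5ccncc5)c4n3)c2)C[C@H](C)N1`, which has not yet been measured in this assay. The change is confined to one spot: 3,5-dimethylpiperazin-1-yl in place of 4-hydroxypiperidin-1-yl on a sulfonyl sulfur. The ring that leaves carries its hydrogen-bond donor on an oxygen, the ring that enters carries it on a ring nitrogen, and the rest of the molecule is untouched.

Among the measured compounds shown here, no measured pair shows this exact exchange, so the direction is a judgement. Compound 3 is expected to give 40000 nM, in the range 10000 nM to 150000 nM, which would mean a step of a 4.0-fold higher number from compound 1 to compound 3 (0.60 log units; beyond the scatter) upward from compound 1, drawn toward, but not reaching, the high value seen for compound 2 at 165000 nM.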

Compound 3, solubility: 180000 nM
Compound 3: middle estimate off by 4.5-fold (0.65 log units), on the low side, outside the stated range (above it).
By their numbers in this assay, from the lowest: compound 1; then compounds 2 and 3 (each within the scatter of the next).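

In this assay, among the compounds shown here, the first comparison confined to one place shows that the group on the sulfonyl sulfur can alone shift the number well beyond the scatter (an 18-fold higher number from compound 1 to compound 3 (1.26 log units; beyond the scatter)), while the rest of the molecule stays the same. The exchange is not a simple one: 4-hydroxypiperidin-1-yl and 3,5-dimethylpiperazin-1-yl have equal counts of hydrogen-bond donors and acceptors, so those counts do not tell them apart, but the entering ring brings a second ring nitrogen, loses the oxygen and has two defined stereocentres. No measurement is available that explains why this step is so large.

This one step cannot separate the contributions of the ring nitrogen, the two methyl groups and their stereochemistry, and a plain piperazin-1-yl ring or a morpholin-4-yl ring on the same sulfonyl sulfur would help to pull them apart. From the compounds shown here alone, it also remains open whether the same exchange would give a step of similar size on a different core, or whether an open-chain amine on the sulfonyl sulfur would behave like either ring.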